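From 4-fluorobenzyl to 4-bromobenzyl: what to expect

The source may hold more compounds than are shown below. What is called first, only, known or untested is meant among the compounds shown, and "the series" means these compounds.

Compound 1 `O=C(NO)c1cnc(N2C[C@@H]3[C@H](C2)[C@H]3NS(=O)(=O)c2cccs2)nc1`: > 10000 nM (a limit)
Compound 2 `O=C(NO)c1cnc(N2C[C@@H]3[C@H](C2)[C@H]3NCc2ccccc2)nc1`: 120 nM
Compound 3 `O=C(NO)c1cnc(N2C[C@@H]3[C@H](C2)[C@H]3NCc2ccc(F)cc2)nc1`: 380 nM
Compound 4 `O=C(NO)c1cnc(N2C[C@@H]3[C@H](C2)[C@H]3NCc2ccc(Br)cc2)nc1`: not yet measured

In a functional assay on HCT-116 cells (Homo sapiens) for antiproliferative activity, read by WST assay, with a stated time of 72 h (on this read-out lower numbers stand for stronger inhibition of growth and higher numbers for weaker inhibition of growth), compound 3 gives 380 nM, the higher of the two actual numbers and so the weaker of those two growth inhibitors. Compound 1 reaches only a limit of the assay, not a number.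

Compound 4 carries bromo in place of fluoro on an aromatic carbon, para to a large group (bromo in place of fluoro on an aromatic carbon). The largest measured steps are an at least 83-fold lower number from compound 1 to compound 2 (1.92 log units; beyond the scatter) and an at least 26-fold lower number from compound 1 to compound 3 (1.42 log units; beyond the scatter). Both replace the (thiophen-2-yl)sulfonyl on an amine nitrogen, a different place from the one changed here, so they offer little guidance. The step that bears directly on this aromatic carbon is a 3.2-fold higher number from compound 2 to compound 3 (0.50 log units; beyond the scatter), which is modest in size. Going by the values given here, that single step cannot establish a trend, and no measured compound yet carries bromo.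

A modest step at most therefore seems likely in this assay, with no clear direction and quite possibly nothing beyond the scatter. The expected step is a 1.1-fold higher number from compound 3 to compound 4 (0.04 log units; within the scatter). The estimate for compound 4 is 420 nM, with an expected range of 140 nM to 1200 nM.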

Compound 4, concentration for 50% growth inhibition: 250 nM
The estimate for compound 4 lay 1.7-fold (0.23 log units) above the measured number; the range from low to high includes it.
By their numbers in this assay, from the lowest: compound 2; then compounds 4 and 3 (each within the scatter of the next). At a limit, above all of these: compound 1.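

In this assay, the step of a 1.5-fold lower number from compound 3 to compound 4 (0.18 log units; within the scatter) does not separate bromo from fluoro, so at this position the exchange of one for the other leaves no reliable mark on growth inhibition. Against the unsubstituted benzyl group, bromo gives a 2.1-fold higher number from compound 2 to compound 4 (0.32 log units; beyond the scatter) and fluoro gives a 3.2-fold higher number from compound 2 to compound 3 (0.50 log units; beyond the scatter) in the same direction, so two compounds rather than one now show a higher number once hydrogen on this aromatic carbon is replaced, and none of the compounds shown goes against this. The 4-bromobenzyl group also keeps the large gap to the sulfonyl compound, with an at least 40-fold lower number from compound 1 to compound 4 (1.60 log units; beyond the scatter) as the step, although this step starts from compound 1, whose value is a limit and not a number: the limit of > 10000 nM in this assay, at which 1 of the 4 values shown sits.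

Going by these compounds, whether a methoxy group, an amine or a carboxylic acid on this aromatic carbon would match or improve on compound 2 remains open. Also unresolved is how growth inhibition would respond to a longer chain in place of the benzyl group on the amine nitrogen.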